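From Compound 2 to Compound 3: A Sulfonyl Group Swap

The compounds below may be only part of what the source reports. "The series", "measured", "known", "first", "only" and "open" are said of these compounds alone.

Within the data shown here, in a functional assay on HL-60 cells (Homo sapiens) for inhibition, read by CCK-8 assay, with a stated time of 48 h, tested at 20 uM (on this read-out higher numbers stand for more inhibition of growth at the one concentration tested and lower numbers for less inhibition of growth), compound 2 (`COc1ccc(S(=O)(=O)Oc2ccccc2/C=C(\C#N)C(=O)Nc2nnc(Cc3ccc(Cl)cc3)s2)cc1`) gives 99% and stands highest of the two numbers so far, well beyond the scatter from the other one. Compound 3 (`N#C/C(=C\c1ccccc1OS(=O)(=O)c1ccccc1[N+](=O)[O-])C(=O)Nc1nnc(Cc2ccc(Cl)cc2)s1`) has 2-nitrophenyl in place of 4-methoxyphenyl on a sulfonyl sulfur. Among the measured compounds shown here, no measured pair shows this change alone. Compound 1 (`N#C/C(=C\c1ccccc1OS(=O)(=O)c1ccccc1[N+](=O)[O-])C(=O)Nc1nnc(Cc2cccc3ccccc23)s1`) also carries 2-nitrophenyl and gives 23% but differs elsewhere too, so a partial drop is expected. The estimated step of a number 34 percentage points lower from compound 2 to compound 3 (beyond the scatter) is a fall beyond the scatter. Compound 3 is expected to give 65% within a range from 30% to 97% once measured.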

Compound 3, percent growth inhibition at one concentration: 19%
Compound 3: middle estimate off by 46 percentage points, on the high side; the measured number lies below the stated range.
By their numbers in this assay, from the lowest: compounds 3 and 1 (each within the scatter of the next); then compound 2.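

On the sulfonyl sulfur, 2-nitrophenyl in place of 4-methoxyphenyl is a large change in this assay and gives a number 80 percentage points lower from compound 2 to compound 3 (beyond the scatter) as a single-place step. With 2-nitrophenyl held on the sulfonyl sulfur, 4-chlorophenyl in place of naphthalen-1-yl on the saturated chain carbon gives a number 4 percentage points lower from compound 1 to compound 3 (within the scatter) and so shows no readable difference. Nothing measured here explains the loss in growth inhibition.

Still open, from the compounds shown here alone, is whether the nitro group or its place on the ring matters. Also open, going by these compounds, is whether a plain phenyl or a methyl on the sulfonyl sulfur would keep the growth inhibition seen with 4-methoxyphenyl.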